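Lengthening the acrylamide in a thienopyrimidine series

The source may report more compounds than this note shows. Statements on the series, on what has been measured and on what is new or still open speak of the compounds shown alone.

The measurements come from a functional assay on A549 cells (Homo sapiens) for inhibition, read by MTT assay, with a stated time of 72 h; on this read-out higher numbers stand for weaker inhibition and lower numbers for stronger inhibition. Compound 1 `C=CC(=O)Nc1cccc(Oc2nc(Nc3cccc(OC)c3)nc3ccsc23)c1` gives 4340 nM in this assay. Compound 3 `C=CC(=O)Nc1cccc(Oc2nc(Nc3cccc(C#N)c3)nc3ccsc23)c1` gives 4340 nM in this assay, so the change no change at the digits printed from compound 1 to compound 3 (within the scatter) leaves the read-out unchanged, and compound 3 stands level with compound 1 on the numbers shown. For the measured compounds named here, compound 2 `COc1ccc(Nc2nc(Oc3cccc(NC(=O)/C=C/C(C)C)c3)c3sccc3n2)cn1` reports only a limit in this assay, > 50000 nM, which is the case described by the limit of > 50000 nM in this assay, at which 1 of the 3 values shown sits, rather than a measured number; compound 2 differs from compound 3 in more than one place, so its value shows only that a larger alkenyl group on the carbonyl, together with a different aryl amine, lies beyond the range measured.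

Compound 4 `CC/C=C/C(=O)Nc1cccc(Oc2nc(Nc3cccc(C#N)c3)nc3ccsc23)c1` is next. The change from compound 3 is but-1-en-1-yl in place of vinyl on a carbonyl carbon. Going by the values given here, the only measured step, from compound 1 to compound 3, alters a substituent on the aromatic ring, not the group on the carbonyl carbon, so no measured step bears directly on this change. With only the limit of compound 2 as a hint, compound 4 is expected to inhibit more weakly than compound 3, with a step of about a 3.5-fold higher number from compound 3 to compound 4 (0.54 log units; beyond the scatter). Compound 4 is therefore estimated at 15000 nM, within a range from 5000 nM to 50000 nM.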

Compound 4, half-maximal inhibitory concentration: 14900 nM
The estimate for compound 4 lay 1.0-fold (0.00 log units) above the measured number; low and high end bracket the measured number.
By their numbers in this assay, from the lowest: compounds 1 and 3 (each within the scatter of the next); then compound 4. At a limit, above all of these: compound 2.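

Swapping vinyl for but-1-en-1-yl on a carbonyl carbon, with the rest of the molecule held fixed, gives a 3.4-fold higher number from compound 3 to compound 4 (0.54 log units; beyond the scatter) in this assay. The earlier step changed only a substituent on the aromatic ring and left the printed number as it was, so this is the first single change shown to move the read-out, and it moves modestly towards weaker inhibition. Compound 2 also carries a larger alkenyl group on the carbonyl, but it differs from compound 3 in more than one place, so it gives no step to read and stands only as a limit: the limit of > 50000 nM in this assay, at which 1 of the 4 values shown sits.

With just two groups compared one-to-one at this carbonyl carbon, the numbers cannot say whether a longer chain would push the read-out further, or whether a chain ending in a dimethylamino group would behave differently from but-1-en-1-yl. As far as these compounds go, the step is also read only with cyano on the aromatic ring, so whether the same swap would shift the number by a similar amount with methoxy there, as in compound 1, remains open.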